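Replacing the methyl on the carbonyl of compound 2

This account rests on a few compounds, and the source may have more. Where it says the series, first, only, none or still open, it means among the compounds named here.

compound 1 `O=C(OC1CCC(CN2CCN(c3cc(=O)c4cc(C(F)(F)F)cc([N+](=O)[O-])c4s3)CC2)CC1)c1ccccc1`: 68.1%
compound 2 `CC(=O)OC1CCC(CN2CCN(c3cc(=O)c4cc(C(F)(F)F)cc([N+](=O)[O-])c4s3)CC2)CC1`: 0%

Among the compounds with values here, in an ADME assay on cells (Hepatocyte, Mus musculus) for metabolic stability, with a stated time of 30 min (on this read-out higher numbers stand for a more stable compound and lower numbers for a less stable compound), compound 2 stands at 0%, the lower of the two numbers, and the only other measured compound, compound 1, gives 68.1%. The next compound, compound 3 `O=C(OC1CCC(CN2CCN(c3cc(=O)c4cc(C(F)(F)F)cc([N+](=O)[O-])c4s3)CC2)CC1)c1ccc(C(F)(F)F)cc1`, departs from compound 2 by one change: 4-(trifluoromethyl)phenyl in place of methyl on a carbonyl carbon. In words, this is 4-(trifluoromethyl)phenyl in place of methyl on a carbonyl carbon.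

Within the data shown here, one measured step bears on it: a number 68.1 percentage points lower from compound 1 to compound 2 (beyond the scatter), with methyl in place of phenyl on a carbonyl carbon. That step is large, and the change to compound 3 runs the opposite way, putting an aromatic ring back in that place. A large rise in this assay is therefore expected, resting on this single pair. Among the measured compounds shown here, no measured compound carries the trifluoromethyl group, so its contribution is unknown, and the range is kept wide. The expected change is a number 62 percentage points higher from compound 2 to compound 3 (beyond the scatter). For compound 3 the estimated value is 62%, with an expected range of 35% to 85%.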

Compound 3, percent of the compound remaining: 28.8%
The estimate for compound 3 lay 33.2 percentage points above the measured number, and the stated range ends above it.
By their numbers in this assay, from the lowest: compound 2; then compound 3; then compound 1.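

In this assay, 4-(trifluoromethyl)phenyl in place of methyl on a carbonyl carbon gives a number 28.8 percentage points higher from compound 2 to compound 3 (beyond the scatter), so a substituted aromatic ring at this place still lifts the read-out above that of the methyl compound. Trifluoromethyl in place of hydrogen on an aromatic carbon gives a number 39.3 percentage points lower from compound 1 to compound 3 (beyond the scatter), which shows that the result at this position depends on what the ring carries and not only on whether a ring is present. The two steps together place the substituted ring between methyl and unsubstituted phenyl, a ranking that rests on these three compounds alone and that no compound shown goes against. Nothing at hand explains why the trifluoromethyl group lowers the number relative to hydrogen.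

From the compounds shown here alone, it remains open whether the drop belongs to trifluoromethyl specifically or would also follow from another group on the same ring, such as a fluorine, a methoxy or a nitrile. Also open, going by these compounds, is whether the ring's benefit over methyl would hold with a longer alkyl chain or a saturated ring such as cyclohexyl on the carbonyl carbon, or with an amide in place of the ester.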